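This account rests on a few compounds, and the source may have more. Where it says the series, first, only, none or still open, it means among the compounds named here.

Compound 1 `CC(C)=CCc1cc(C(=O)Nc2cc3ccc(OCCCN4CCCCC4)c(C)c3oc2=O)ccc1O`: > 50000 nM
Compound 2 `CC(C)=CCc1cc(C(=O)Nc2cc3ccc(OCCCNCC(C)C)c(C)c3oc2=O)ccc1O`: 1030 nM

Both compounds were tested in a functional assay on SK-BR-3 cells (Homo sapiens) for antiproliferative activity; on this read-out higher numbers stand for weaker inhibition and lower numbers for stronger inhibition. The entry for compound 1, > 50000 nM, is a limit and not a number. Among the compounds with values here, compound 2, at 1030 nM, therefore holds the only true number so far. Compound 3 `COC(=O)CNCCCOc1ccc2cc(NC(=O)c3ccc(O)c(CC=C(C)C)c3)c(=O)oc2c1C` has not yet been measured. It departs from compound 2 by methoxycarbonyl in place of isopropyl on a saturated chain carbon bound to an amine nitrogen. Within the data shown here, one measured step bears on this, since it also alters the group on that amine: an at least 48-fold lower number from compound 1 to compound 2 (1.68 log units; beyond the scatter). This large step is a different exchange, so it gives no firm direction, but it shows that the number can move far with this group. A moderate rise in the number is therefore expected, and the estimated change is a 2.9-fold higher number from compound 2 to compound 3 (0.46 log units; beyond the scatter). The estimated value for compound 3 is 3000 nM, with an expected range of 800 nM to 12000 nM.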

Compound 3, half-maximal inhibitory concentration: 1060 nM
For compound 3 the middle estimate is 2.8-fold (0.45 log units) above the measured one, and the stated range covers the measured number.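

Methoxycarbonyl in place of isopropyl on a saturated chain carbon bound to an amine nitrogen gives a 1.0-fold higher number from compound 2 to compound 3 (0.01 log units; within the scatter), so in this assay this position accepts the ester group with no change beyond the scatter. The new compound also repeats the large step seen earlier, with an at least 47-fold lower number from compound 1 to compound 3 (1.67 log units; beyond the scatter) standing alongside an at least 48-fold lower number from compound 1 to compound 2 (1.68 log units; beyond the scatter); among the three compounds, piperidin-1-yl is the group that stands apart, while isobutylamino and ((methoxycarbonyl)methyl)amino do not differ beyond the scatter. Compound 1 remains the one compound held at a limit and not a number: the limit of > 50000 nM in this assay, at which 1 of the 3 values shown sits.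

The compounds shown leave open whether a carboxylic acid in place of the methoxycarbonyl, or a longer chain carrying it, would keep this level. They also leave open whether diethylamino would behave like piperidin-1-yl or like isobutylamino.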